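Aryl for Anilino Switch Against a Silent Baseline

The source may hold more compounds than are shown below. What is called first, only, known or untested is meant among the compounds shown, and "the series" means these compounds.

Compound 1 `Cc1cc(Cc2ccsc2)c(=O)n(CC(=O)Nc2ccc(Br)cc2)n1` — > 50000 nM (a limit of the assay)
Compound 2 `COc1ccc(Nc2cc(C)nn(CC(=O)Nc3ccc(Br)cc3)c2=O)cc1` — > 50000 nM (a limit of the assay)

In an assay on HL-60 cells for agonist activity at N-formyl peptide receptor 3 (Homo sapiens), read by calcium flux (on this read-out higher numbers stand for an effect only at larger amounts of compound and lower numbers for an effect already at smaller amounts), compound 1 gives > 50000 nM, which is a limit of the assay and not a number. Compound 2 gives > 50000 nM in this assay, again a limit and not a number. For the measured compounds named here, the single measured step, a step that the two limits leave unreadable from compound 1 to compound 2, is therefore of unreadable size, because both of its ends sit at the limit of > 50000 nM in this assay, at which 2 of the 2 values shown sit.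

Compound 3 `COc1ccc(-c2cc(C)nn(CC(=O)Nc3ccc(Br)cc3)c2=O)cc1` is the next structure, and it differs from compound 2 by 4-methoxyphenyl in place of (4-methoxyphenyl)amino on an aromatic carbon. No measured step touches this kind of change, and the one step shown carries no readable size. Compound 2 itself shows no effect within the measured range, so nothing points to a gain or a loss beyond the scatter. Compound 3 is accordingly expected to show 40000 nM, with an estimated range from 5000 nM to 200000 nM. The expected step of an at least 1.2-fold lower number from compound 2 to compound 3 (0.09 log units; that floor lies within the scatter) is thus estimated to stay near the limit, with a fair chance that only a limit is reported.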

Compound 3, half-maximal effective concentration: > 50000 nM
Compound 3 gave a limit, no number; the forecaster's own chance of this, stated with the estimate: 70%; at least 1.2-fold (0.09 log units) between middle value and limit.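

In this assay compound 3 gives > 50000 nM, a limit of the assay and not a number. No step from compound 2 to compound 3 or from compound 1 to compound 3 can be read, because all three compounds sit at the same limit: the limit of > 50000 nM in this assay, at which 3 of the 3 values shown sit.

The compounds shown leave open whether (thiophen-3-yl)methyl, (4-methoxyphenyl)amino and 4-methoxyphenyl differ at all in this assay.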